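The source may report more compounds than this note shows. Statements on the series, on what has been measured and on what is new or still open speak of the compounds shown alone.

In a physicochemical assay for solubility, read by HPLC, in phosphate buffer, at pH 6.5 (a lower number here means a less soluble compound, a higher number a more soluble compound), compound 1 (`COC(=O)C1=C(CN2CCCCC2)NC(c2nccs2)=NC1(C)c1ccc(F)cc1`) gives 282 ug/mL and compound 2 (`COC(=O)C1=C(CN2CCNCC2)NC(c2nccs2)=NC1(C)c1ccc(F)cc1`) gives 250 ug/mL, with a 1.1-fold lower number from compound 1 to compound 2 (0.05 log units; within the scatter). Compound 3 (`COC(=O)C1=C(CN2CCC(O)CC2)NC(c2nccs2)=NC1(C)c1ccc(F)cc1`) stands highest of the three at 593 ug/mL. Compound 4 (`COC(=O)C1=C(CN2CCC(F)(F)CC2)NC(c2nccs2)=NC1(C)c1ccc(F)cc1`) carries 4,4-difluoropiperidin-1-yl in place of 4-hydroxypiperidin-1-yl on a saturated chain carbon bound to a double-bonded ring carbon. For the measured compounds named here, two measured steps bear on this change: a 2.1-fold higher number from compound 1 to compound 3 (0.32 log units; beyond the scatter), on adding the hydroxy, and a 2.4-fold higher number from compound 2 to compound 3 (0.38 log units; beyond the scatter). Both are modest. Going by the values given here, compound 4 lacks that hydroxy, and no measured compound carries 4,4-difluoropiperidin-1-yl, so a modest drop is expected in this assay. The expected step is a 2.5-fold lower number from compound 3 to compound 4 (0.39 log units; beyond the scatter). For compound 4 the estimate is 240 ug/mL, with an expected range of 100 ug/mL to 500 ug/mL.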

Compound 4, solubility: < 1 ug/mL
Compound 4: no number, only a limit; the forecaster's own chance of this, stated with the estimate: 5%; middle value at least 240-fold (2.38 log units) away from the limit.
By their numbers in this assay, from the lowest: compounds 2 and 1 (each within the scatter of the next); then compound 3. At a limit, below all of these: compound 4.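

In this assay compound 4 gives < 1 ug/mL as a limit, not a number. Placing 4,4-difluoropiperidin-1-yl in place of 4-hydroxypiperidin-1-yl (an at least 590-fold lower number from compound 3 to compound 4 (2.77 log units; beyond the scatter)), piperazin-1-yl (an at least 250-fold lower number from compound 2 to compound 4 (2.39 log units; beyond the scatter)) or piperidin-1-yl (an at least 280-fold lower number from compound 1 to compound 4 (2.45 log units; beyond the scatter)) gives a large step each time, whereas the earlier changes at this place were modest or within the scatter. Compound 4 alone of the four compounds sits at that limit: the limit of < 1 ug/mL in this assay, at which 1 of the 4 values shown sits.

On these data alone, how far under the limit compound 4 lies remains open. Also open, as far as these compounds go, is whether a single fluorine, a methoxy on the piperidine or a morpholine at this place would keep the number close to those of compounds 1, 2 and 3.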